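The source may report more compounds than this note shows. Statements on the series, on what has been measured and on what is new or still open speak of the compounds shown alone.

Measured in a functional assay on SK-BR-3 cells (Homo sapiens) for cytotoxicity, read by MTT assay, with a stated time of 72 h; a higher number here means that more compound is needed for the effect, a lower number that less compound is needed:
compound 1, `COc1ccc(Nc2cc(C3CCCCC3)oc(=O)c2)cc1`: 5.29 uM
compound 2, `O=c1cc(Nc2ccc(Br)cc2)cc(-c2ccccc2)o1`: 0.4 uM
compound 3, `O=c1cc(NC2CCCCC2)cc(/C=C/c2ccccc2)o1`: 1.53 uM

Compound 1 gives the highest of the three numbers in this assay; compound 3 is nearest to it, with a lower number beyond the scatter, and compound 2 is furthest, also beyond the scatter. Going by the values given here, no pair of measured compounds differs in one place, so no measured step is available.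

Compound 4, `COc1ccc(Nc2cc(-c3ccco3)oc(=O)c2)cc1`, is not yet measured; its difference from compound 1 is furan-2-yl in place of cyclohexyl on an aromatic carbon.

Compound 2 gives 0.4 uM and compound 3 gives 1.53 uM, both well under compound 1, though each differs from compound 1 in more than one place. On that basis a downward step beyond the scatter is expected, a 2.6-fold lower number from compound 1 to compound 4 (0.42 log units; beyond the scatter). Compound 4 is estimated at 2 uM, with a range of 0.7 uM to 6 uM.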

Compound 4, concentration for half-maximal effect: 1.76 uM
Estimate against measurement, compound 4: 1.1-fold (0.06 log units) above; measured number inside the range.
By their numbers in this assay, from the lowest: compound 2; then compounds 3 and 4 (each within the scatter of the next); then compound 1.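

Furan-2-yl in place of cyclohexyl, next to the ring oxygen, gives the only one-place comparison in the series: in this assay the change yields a 3.0-fold lower number from compound 1 to compound 4 (0.48 log units; beyond the scatter) as a step beyond the scatter. This position therefore responds to the group it carries, and a ring of carbon only is not needed there for activity in this assay. No measurement on hand accounts for the step.

Open, as far as these compounds go, is whether the lower number belongs to furan-2-yl specifically or extends to thiophen-2-yl or an open chain such as n-butyl at this carbon. From the compounds shown here alone, with a single pair behind it, the size of the step with a different group on the amine nitrogen also remains unknown.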